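This account rests on a few compounds, and the source may have more. Where it says the series, first, only, none or still open, it means among the compounds named here.

Compound 1 `Cc1cc(S(=O)(=O)/N=C(\N)n2nccc2-c2ccccc2)c(SCc2ccccc2Cl)cc1Cl` is the starting point. In an ADME assay on microsomes from liver (Homo sapiens) for metabolic stability, read by LC-MS, using NADPH, tested at 5 uM (a lower number here means that the compound disappears faster, a higher number that the compound lasts longer), compound 1 gives 0.226 h. Two companions vary the group on the saturated chain carbon bound to a sulfur: compound 2 `Cc1cc(S(=O)(=O)/N=C(\N)n2nccc2-c2ccccc2)c(SCc2cccc(Cl)c2)cc1Cl` gives 0.309 h in this assay, and compound 3 `Cc1cc(S(=O)(=O)/N=C(\N)n2nccc2-c2ccccc2)c(SCc2cccc3ccccc23)cc1Cl` gives 0.268 h. Compound 1 thus has the smallest of the three numbers, yet the step of a 1.4-fold higher number from compound 1 to compound 2 (0.14 log units; within the scatter) and the step of a 1.2-fold higher number from compound 1 to compound 3 (0.07 log units; within the scatter) both stay inside the scatter, as does a 1.2-fold lower number from compound 2 to compound 3 (0.06 log units; within the scatter), so the three compounds cannot be separated in this assay.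

Compound 4 `Cc1cc(-c2ccccc2)n(/C(N)=N/S(=O)(=O)c2cc(C)c(Cl)cc2SCc2ccccc2Cl)n1` differs from compound 1 by methyl in place of hydrogen on an aromatic carbon. Within the data shown here, none of the measured steps touches this five-membered aromatic ring; all three concern the group on the saturated chain carbon bound to a sulfur, and all three are within the scatter. Among the measured compounds shown here, there is therefore no measured step that bears on the change from compound 1 to compound 4, and the only guidance is that every variation seen so far has left this assay essentially unmoved. On that basis, compound 4 is expected to show a 1.0-fold higher number from compound 1 to compound 4 (0.01 log units; within the scatter), a step that is not expected to exceed the scatter. The estimate for compound 4 in this assay is 0.23 h, with a range from 0.12 h to 0.45 h.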

Compound 4, half-life: 0.163 h
Compound 4: the middle estimate sits 1.4-fold (0.15 log units) above what was measured; the measured number falls inside the stated range.
By their numbers in this assay, from the lowest: compounds 4, 1, 3 and 2 (each within the scatter of the next).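

Among these compounds, compounds 1 to 3 spoke only to the group on the saturated chain carbon bound to a sulfur, whereas compound 4 gives a first reading at a second place in the molecule, an aromatic carbon of the five-membered aromatic ring with 2 nitrogen, two ring bonds from the ring atom that bears a phenyl group. In this assay, methyl in place of hydrogen there gives a 1.4-fold lower number from compound 1 to compound 4 (0.14 log units; within the scatter), so this position, like the group on the chain carbon, shows no step beyond the scatter for the one change shown. Nothing available gives a reason for this result or connects it with any measured property of the methyl group.

A single methyl group is the only replacement of hydrogen shown at this position, so it stays open whether a longer chain such as propyl, a ring such as phenyl, an amine or a carboxylic acid on the same carbon would move the half-life beyond the scatter. Going by these compounds, it also stays open whether methyl at this position would give a similar step when the 2-chlorophenyl group of compound 1 is replaced by the 3-chlorophenyl group of compound 2 or the naphthalen-1-yl group of compound 3.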